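The compounds below may be only part of what the source reports. "The series", "measured", "known", "first", "only" and "open" are said of these compounds alone.

Series notes. The shared core of compound 1 `O=[N+]([O-])c1ccc(Nc2cncc(N3CC4CC(C3)N4)c2)cc1` carries an anilino group on a pyridine-type ring that also bears a bridged bicyclic diamine; in an assay on cell membranes for displacement of a labelled ligand from Neuronal acetylcholine receptor; alpha4/beta2 (Rattus norvegicus) (a higher number here means a weaker inhibitor, a lower number a stronger inhibitor), compound 1 gives 0.0225 nM. Compound 2 `Fc1ccc(Nc2cncc(N3CC4CC(C3)N4)c2)cc1` keeps everything but the nitro group; in this assay compound 2 gives 0.091 nM. Going by the values given here, the one step that can be read within the measured set, a 4.0-fold higher number from compound 1 to compound 2 (0.61 log units; beyond the scatter), is a modest loss. Compound 3 `CN(c1ccccc1)c1cncc(N2CC3CC(C2)N3)c1` differs from the others in two ways at once, a methyl on the bridging nitrogen and no substituent on the outer phenyl ring, and in this assay compound 3 gives 2.06 nM, the highest number of the three and well apart from both compound 1 and compound 2.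

Compound 4 `c1ccc(Nc2cncc(N3CC4CC(C3)N4)c2)cc1` is to be measured in this assay. The change from compound 3 is hydrogen in place of methyl on a nitrogen on an aromatic ring. Among the compounds with values here, no measured pair isolates this change: the only step on record, a 4.0-fold higher number from compound 1 to compound 2 (0.61 log units; beyond the scatter), concerns the phenyl substituent, not the nitrogen. What can be said is that compound 1 and compound 2, both unmethylated at that nitrogen, sit far below compound 3, so removing the methyl is expected to bring the number down toward the range of compound 2; a drop of about a 10-fold lower number from compound 3 to compound 4 (1.01 log units; beyond the scatter) is expected. Compound 4 is therefore estimated at 0.2 nM, within 0.05 nM to 0.8 nM.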

Compound 4, inhibition constant: 0.0807 nM
The estimate for compound 4 lay 2.5-fold (0.39 log units) above the measured number; low and high end bracket the measured number.
By their numbers in this assay, from the lowest: compound 1; then compounds 4 and 2 (each within the scatter of the next); then compound 3.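

In this assay the methyl on the nitrogen on an aromatic ring can now be read on its own: with hydrogen in its place there is a 26-fold lower number from compound 3 to compound 4 (1.41 log units; beyond the scatter) and a large change, so the high number of compound 3 goes with that methyl. On the outer ring, a 1.1-fold lower number from compound 2 to compound 4 (0.05 log units; within the scatter) leaves fluoro and hydrogen not told apart, whereas a 3.6-fold higher number from compound 1 to compound 4 (0.55 log units; beyond the scatter) and the step on record from nitro to fluoro together set nitro apart from both, by a modest margin. Nothing on hand bears on the reason for either the methyl step or the nitro step.

As far as these compounds go, the methyl appears here only with an unsubstituted phenyl ring, so its size with nitro or fluoro on that ring stays open, as does the outcome with an ethyl or acetyl group on the same nitrogen. Also open, from the compounds shown here alone, is whether an amine, a methoxy group or a carboxylic acid on the outer ring would fall with nitro or with fluoro and hydrogen.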